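Bromo in place of methyl in a series at the limit

The source may report more compounds than this note shows. Statements on the series, on what has been measured and on what is new or still open speak of the compounds shown alone.

Compound 3 `Cc1cc(Nc2ccccc2C)nc(N)n1` is the point of departure. In an assay on cells for inhibition of S-adenosylmethionine decarboxylase proenzyme (Homo sapiens), read by mass spectrometry, at pH 7.2 (a lower number here means a stronger inhibitor, a higher number a weaker inhibitor), compound 3 gives only a limit, > 180000 nM. Compound 1 `Cc1cc(Nc2cc(C(=O)O)cc(C(=O)O)c2)nc(N)n1` likewise gives only a limit in this assay, > 180000 nM. Compound 2 `Cc1cc(Nc2cc(Cl)ccc2Cl)nc(N)n1` also gives only a limit in this assay, > 180000 nM. Among the measured compounds shown here, compound 3 thus stands with the others at the limit of > 180000 nM in this assay, at which 3 of the 3 values shown sit, and no measured pair shows how far any single change moves the number. The new member is compound 4 `Cc1cc(Nc2ccccc2Br)nc(N)n1`, derived from compound 3 by bromo in place of methyl on an aromatic carbon. For the measured compounds named here, with all values at the limit, no step in this assay beyond the scatter is expected in either direction. Compound 4 is expected to give 200000 nM, between 100000 nM and 1000000 nM, most likely again only as a limit. The expected step is a step that the limit leaves unreadable from compound 3 to compound 4.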

Compound 4, half-maximal inhibitory concentration: > 180000 nM
Compound 4 was reported as a limit; the forecaster's own chance of this, stated with the estimate: 85%; the middle value lies beyond the limit too.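

Compound 3 and compound 4 are both reported only as limits, and no step can be read for bromo in place of methyl. The compounds shown leave open which change to the shared core, if any, brings a value within the readable range of this assay.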